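The compounds below may be only part of what the source reports. "The series", "measured", "known", "first", "only" and "open" are said of these compounds alone.

Measured in a functional assay on HT-29 cells (Homo sapiens) for antiproliferative activity, read by MTT assay, with a stated time of 72 h; a lower number here means a stronger inhibitor, a higher number a weaker inhibitor:
Compound 1 `C=CC(=O)Nc1nc(-c2ccccc2)cs1`: 6600 nM
Compound 2 `C=CC(=O)N(CC(=O)NC1COC1)c1nc(-c2ccccc2)cs1`: > 30000 nM

Compound 2 has no number in this assay, and its > 30000 nM is a limit of the assay. Its standing is the limit of > 30000 nM in this assay, at which 1 of the 2 values shown sits.

The next compound to read is compound 3 `C=CC(=O)N(Cc1cccnc1)c1nc(-c2ccccc2)cs1`. The change is pyridin-3-yl in place of (oxetan-3-yl)carbamoyl on a saturated chain carbon bound to an amide-type nitrogen.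

Within the data shown here, one measured step bears on this, an at least 4.5-fold higher number from compound 1 to compound 2 (0.65 log units; beyond the scatter), which is beyond the scatter and is itself bounded only on one side. Compound 3 keeps a substituted amide-type nitrogen, so a full return to the level of compound 1 at 6600 nM is not expected. Among the measured compounds shown here, no measured step covers pyridin-3-yl, which leaves the size of any gain open. A modest move to a lower number in this assay is expected, though a second limit reading would be no surprise. The expected change is an at least 1.5-fold lower number from compound 2 to compound 3 (0.19 log units; that floor lies within the scatter). For compound 3 the estimate is 19000 nM, with an expected range of 8000 nM to 35000 nM.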

Compound 3, half-maximal inhibitory concentration: > 30000 nM
Compound 3: no number, only a limit (the forecaster's own chance of this, stated with the estimate: 45%); middle value at least 1.5-fold (0.19 log units) from the limit.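

In this assay, compound 3 gives no number, and its reading is a limit of the assay, the same limit that compound 2 reached: the limit of > 30000 nM in this assay, at which 2 of the 3 values shown sit. The new information is that the loss is not confined to the (oxetan-3-yl)carbamoyl substituent: (pyridin-3-yl)methyl in place of hydrogen on the amide-type nitrogen also gives an at least 4.5-fold higher number from compound 1 to compound 3 (0.65 log units; beyond the scatter). Within these three compounds, both substituted amides read weaker than the amide with its hydrogen in place, even though the group on the saturated chain carbon changes from one with a hydrogen-bond donor to a six-membered aromatic ring with none, and no compound shown goes against this; the step between compound 2 and compound 3 cannot be read, so the two groups cannot be ranked at this place.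

Open, as far as these compounds go, is whether a methyl group on the amide-type nitrogen would hold the level of compound 1 at 6600 nM. Such a compound could instead also fall to the limit of the assay. Also open, from the compounds shown here alone, is how an amine or a carboxylic acid on a saturated chain carbon bound to an amide-type nitrogen would read in this assay.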